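A few compounds are considered here, and "the series" means these few. Any claim that something is new, unique, unknown or untested is made for them only; others in the source may bear on it.

Compound 1, `O=C1C=CCC(/C=C/c2ccccc2)N1`, is the parent of this small set. In an ADME assay on HaCaT cells (Homo sapiens) for inhibition, read by sulforhodamine B assay, with a stated time of 48 h (on this read-out lower numbers stand for stronger inhibition of growth and higher numbers for weaker inhibition of growth), compound 1 gives only a limit of the assay, > 1250 uM. Compound 2, `O=C1C=CCC(/C=C/c2ccc(C(F)(F)F)cc2)N1`, carries a trifluoromethyl in place of hydrogen on an aromatic carbon, and in this assay compound 2 gives 174 uM, so that the set shows an at least 7.1-fold lower number from compound 1 to compound 2 (0.85 log units; beyond the scatter). Compound 3, `COc1ccc(/C=C/C2CC=CC(=O)N2)cc1`, instead carries a methoxy in place of hydrogen on an aromatic carbon. In this assay compound 3 gives only a limit of the assay, > 1090 uM. Compound 3 thus stands among the values that are limits rather than numbers; the set shows a step that the two limits leave unreadable from compound 1 to compound 3, while against compound 2 it shows an at least 6.2-fold higher number from compound 2 to compound 3 (0.79 log units; beyond the scatter). The untested compound 4, `COc1ccc(/C=C/C2CC=CC(=O)N2)cc1OC`, differs from compound 3 as follows: methoxy in place of hydrogen on an aromatic carbon. Going by the values given here, the only measured step of the same kind, a step that the two limits leave unreadable from compound 1 to compound 3, cannot be read, so no step beyond the scatter is expected in this assay in either direction. Compound 4 is therefore expected to sit near 1000 uM, between 300 uM and 3000 uM. That expectation amounts to an at least 1.0-fold lower number from compound 3 to compound 4 (0.03 log units; that floor lies within the scatter).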

Compound 4, concentration for growth inhibition (reported as GI): > 964 uM
Compound 4: only a limit was reported (the forecaster's own chance of this, stated with the estimate: 70%); the middle value lies beyond the limit too.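

Compound 4 gives > 964 uM as a limit of the assay and not a number. Compound 3 also gives only a limit, so the step between compound 3 and compound 4 cannot be read. The compounds shown leave open whether the added methoxy of compound 4 changes anything in this assay at all.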